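The compounds below may be only part of what the source reports. "The series", "measured", "known", "first", "only" and "open" are said of these compounds alone.

Measured compounds in an assay on isolated protein for inhibition of Aromatase (Homo sapiens), read by fluorescence, using NADPH, with a stated time of 30 min, tested at 50 uM; a higher number here means more inhibition at the concentration tested (going by the name of the read-out), a lower number less inhibition:
compound 1, `C#CCn1c(-c2ccccc2)cc2ccccc21`, gives 26.3%
compound 2, `Clc1ccccc1-c1cc2ccccc2[nH]1`, gives 21.5%
compound 3, `COCn1c(-c2ccccc2)cc2ccccc21`, gives 20.2%

Compound 3 has the lowest of the three numbers, but its nearest neighbour is compound 2, whose number is higher by an amount within the scatter, and even compound 1, the furthest, is within the scatter of it. None of the three can be ranked against the others.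

The step to compound 4, `c1ccc(Cn2c(-c3ccccc3)cc3ccccc32)cc1`, is phenyl in place of methoxy on a saturated chain carbon bound to an aromatic nitrogen. Going by the values given here, only one measured step touches the same place: a number 6.1 percentage points lower from compound 1 to compound 3 (within the scatter), which lies within the scatter. Swapping one group for another on this saturated chain carbon bound to an aromatic nitrogen has so far left this assay unmoved, and nothing in the data speaks for the benzyl arrangement behaving otherwise. The expected step is therefore none beyond the scatter, a number 2.8 percentage points higher from compound 3 to compound 4 (within the scatter). Compound 4 is estimated at 23%, with a range from 10% to 38%.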

Compound 4, a percentage reported as inhibition, at one concentration (the size of the read-out at that concentration, not a potency): 0%
Beside the measured number, compound 4's estimate is 23 percentage points above it; the measured number lies below the stated range.
By their numbers in this assay, from the lowest: compound 4; then compounds 3, 2 and 1 (each within the scatter of the next).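

In this assay the saturated chain carbon bound to an aromatic nitrogen turns out not to be indifferent to what it carries: phenyl in place of methoxy gives a number 20.2 percentage points lower from compound 3 to compound 4 (beyond the scatter) and phenyl in place of ethynyl gives a number 26.3 percentage points lower from compound 1 to compound 4 (beyond the scatter) on the same core. Methoxy and ethynyl had stayed within the scatter of each other, so the only change at this place that registers is the one that brings in a six-membered aromatic ring of carbon only, methoxymethyl to benzyl in the wider cut. Nothing available here accounts for this drop.

As far as these compounds go, whether the aromatic ring itself or simply a larger group goes with the lower number stays open, and a cyclohexylmethyl group or a longer chain on this carbon would separate the two. From the compounds shown here alone, how an amine or a carboxylic acid carried at this place would read also remains open.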